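A Fluorine on the Core: What Potency to Expect

The source may report more compounds than this note shows. Statements on the series, on what has been measured and on what is new or still open speak of the compounds shown alone.

Of the compounds shown here, three built on one shared core have been tested in a functional assay on HT-29 cells (Homo sapiens) for cytotoxicity, read by MTT assay, with a stated time of 2 days; a higher number here means a weaker inhibitor, a lower number a stronger inhibitor. Compound 1 `c1coc(CNc2nc(NCCCN3CCCC3)nc3ccccc23)c1` gives 6010 nM. Compound 2 `Clc1cccc(N2CCN(CCCCNc3nc(NCc4ccco4)c4ccccc4n3)CC2)c1Cl` gives 3370 nM, and compound 3 `Cc1cccc(N2CCN(CCCCNc3nc(NCc4ccco4)c4ccccc4n3)CC2)c1C` gives 860 nM. Of the three numbers, that of compound 2 is the second highest, though its gap to compound 1 falls within the scatter, so the two cannot be told apart; compound 3 lies beyond the scatter. Going by the values given here, the only step between compounds differing in one place is a 3.9-fold lower number from compound 2 to compound 3 (0.59 log units; beyond the scatter), where a 2,3-dimethylphenyl stands in place of a 2,3-dichlorophenyl on an amine nitrogen in a ring.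

Compound 4 `Fc1ccc2nc(NCCCCN3CCN(c4cccc(Cl)c4Cl)CC3)nc(NCc3ccco3)c2c1` differs from compound 2 in another part of the molecule: fluoro in place of hydrogen on an aromatic carbon. Among the compounds with values here, no measured step concerns a fluoro entering on an aromatic carbon of the fused two-ring system, and the step from compound 2 to compound 3 alters an unrelated group, so it offers no guide to direction. The expectation is therefore a step of a 1.1-fold lower number from compound 2 to compound 4 (0.05 log units; within the scatter), nothing beyond the scatter. Compound 4 is accordingly estimated at 3000 nM, with a range from 1200 nM to 7500 nM.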

Compound 4, half-maximal inhibitory concentration: 390 nM
Beside the measured number, compound 4's estimate is 7.7-fold (0.89 log units) above it, and the stated range ends above it.
By their numbers in this assay, from the lowest: compound 4; then compound 3; then compounds 2 and 1 (each within the scatter of the next).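

The earlier step showed the number moving with a change on the phenyl group, and this one shows that the core matters too. In this assay, fluoro in place of hydrogen, on an aromatic carbon of the six-membered carbon ring in the fused system, gives an 8.6-fold lower number from compound 2 to compound 4 (0.94 log units; beyond the scatter). So a change of one heavy atom at this position is enough to take the number beyond the scatter, although no available data explain why.

As far as these compounds go, it remains open whether this step belongs to fluoro itself, which a chloro or methoxy group on the same carbon would help to show, or whether fluoro elsewhere on that ring would behave alike. Also open, from the compounds shown here alone, is whether the same fluoro would give a similar step on compound 3, which carries 2,3-dimethylphenyl.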